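The compounds below may be only part of what the source reports. "The series", "measured", "known", "first", "only" and "open" are said of these compounds alone.

In a functional assay on HeLa cells (Homo sapiens) for antiproliferative activity, read by CCK-8 assay, with a stated time of 72 h (on this read-out lower numbers stand for stronger inhibition and higher numbers for weaker inhibition), three compounds with a shared core have been measured. Compound 1 `COc1ccc(-c2cncnc2-c2cc(OC)c(OC)c(OC)c2)cc1O` gives 280 nM, compound 2 `COc1ccc(-c2cncnc2-c2cc(OC)c(OC)c(OC)c2)cc1Cl` gives 320 nM, and compound 3 `CCSc1ccc(-c2cncnc2-c2cc(OC)c(OC)c(OC)c2)cc1` gives 370 nM. Compound 3 therefore stands level with the other two, as the steps show: a 1.3-fold higher number from compound 1 to compound 3 (0.12 log units; within the scatter) and a 1.2-fold higher number from compound 2 to compound 3 (0.06 log units; within the scatter).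

Compound 4 `COc1cc(-c2ncncc2-c2ccc(OC(C)C)cc2)cc(OC)c1OC` keeps the core of compound 3 and changes one group: isopropoxy in place of ethylsulfanyl on an aromatic carbon. Isopropoxy takes the place of ethylsulfanyl on an aromatic carbon, para to a large group. Among the measured compounds shown here, no measured step makes this exact swap. The closest evidence comes from the two steps above, which also altered the groups on this six-membered aromatic ring of carbon only, and neither moved the number beyond the scatter. The step from compound 1 to compound 2 tells the same story: a 1.1-fold higher number from compound 1 to compound 2 (0.06 log units; within the scatter). A step within the scatter is therefore expected in this assay, with no firm direction. The expected step is a 1.1-fold higher number from compound 3 to compound 4 (0.03 log units; within the scatter). For compound 4, the estimated value is 400 nM, with an expected range of 130 nM to 1200 nM.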

Compound 4, half-maximal inhibitory concentration: 8360 nM
Compound 4: middle estimate off by 21-fold (1.32 log units), on the low side; the whole stated range lies below it.
By their numbers in this assay, from the lowest: compounds 1, 2 and 3 (each within the scatter of the next); then compound 4.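

In this assay, the aromatic carbon para to a large group proves sensitive to what sits on it: isopropoxy in place of ethylsulfanyl gives a 23-fold higher number from compound 3 to compound 4 (1.35 log units; beyond the scatter). The steps among compound 1, compound 2 and compound 3 all stayed within the scatter, yet this one swap lies far beyond it, which shows that a ring able to accept those earlier groups does not accept every group. Ethylsulfanyl and isopropoxy have the same counts of hydrogen-bond donors and acceptors and no net charge, and no measurement offered here accounts for the large step.

Open, as far as these compounds go, is whether the step follows from the oxygen in place of sulfur or from the branched chain. An ethoxy group here would change only the atom relative to compound 3, and an isopropylsulfanyl group would change only the chain.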